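Swapping an oxane for a fluorophenyl: solubility outlook

The compounds below may be only part of what the source reports. "The series", "measured", "known", "first", "only" and "open" are said of these compounds alone.

Compound 1 `CNC(=O)c1cccn(Cc2ccccc2)c1=O` gives 78 ug/mL.
Compound 2 `CNC(=O)c1cc(C(=O)NC2CC2)cn(CC2CCOCC2)c1=O` gives >= 165 ug/mL.

In a physicochemical assay for solubility (on this read-out lower numbers stand for lower solubility and higher numbers for higher solubility), compound 2 stands at the limit of the assay; its reading of >= 165 ug/mL is a limit, not a number, as shown by the limit of >= 165 ug/mL in this assay, at which 1 of the 2 values shown sits. Compound 3 `CNC(=O)c1cc(C(=O)NC2CC2)cn(Cc2ccccc2F)c1=O` is the unmeasured partner, differing from compound 2 by 2-fluorophenyl in place of oxan-4-yl on a saturated chain carbon bound to an aromatic nitrogen. Among the compounds with values here, no measured step covers this change, and compound 1 carries a benzyl group with 78 ug/mL. A drop beyond the scatter is expected, an at least 2.7-fold lower number from compound 2 to compound 3 (0.43 log units; beyond the scatter). Compound 3 is therefore estimated at 60 ug/mL, between 20 ug/mL and 150 ug/mL.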

Compound 3, solubility: >= 145 ug/mL
Compound 3 was reported as a limit; the forecaster's own chance of this, stated with the estimate: 10%; middle value at least 2.4-fold (0.38 log units) from the limit.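

Within the data shown here, no step from compound 2 to compound 3 can be read in this assay, as the readings of both compounds are limits and not numbers. Going by these compounds, whether 2-fluorophenyl in place of oxan-4-yl shifts the reading at all, and by how much, remains open.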